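The compounds below may be only part of what the source reports. "The series", "measured", "known", "first", "only" and "open" are said of these compounds alone.

Compound 1 `Cc1cc(=O)c2c(O)c(CN(C)CC(=O)O)c(O)c([C@H]3CCN(C)C[C@H]3O)c2o1`: 18%
Compound 2 `CCOC(=O)N1CCN(Cc2c(O)c([C@H]3CCN(C)C[C@H]3O)c3oc(C)cc(=O)c3c2O)CC1`: 18%

Measured in a functional assay on Caco-2 cells (Homo sapiens) for inhibition, read by MTT assay, with a stated time of 48 h, tested at 10 uM (on this read-out lower numbers stand for less inhibition of growth and higher numbers for more inhibition of growth at the one concentration tested), and level with compound 1, compound 2 stands at 18%. Compound 3 `Cc1cc(=O)c2c(O)c(CN3CC(O)CC3C(=O)O)c(O)c([C@H]3CCN(C)C[C@H]3O)c2o1` is next, with 2-carboxy-4-hydroxypyrrolidin-1-yl in place of 4-(ethoxycarbonyl)piperazin-1-yl on a saturated chain carbon bound to an aromatic carbon. Among the compounds with values here, only one measured step bears on this place, no change at the digits printed from compound 1 to compound 2 (within the scatter). It is a single step, so it gives thin support, but no shift beyond the scatter is expected in this assay. The expected step is no change at the digits printed from compound 2 to compound 3 (within the scatter). For compound 3 the estimate is 18%, with an expected range of 7% to 30%.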

Compound 3, percent growth inhibition at one concentration: 19%
Compound 3: middle estimate off by 1 percentage points, on the low side, within the range that was stated.
By their numbers in this assay, from the lowest: compounds 1, 2 and 3 (each within the scatter of the next).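

Notes on the place on a saturated chain carbon bound to an aromatic carbon: in this assay, the five-membered 2-carboxy-4-hydroxypyrrolidin-1-yl gives a number 1 percentage points higher from compound 2 to compound 3 (within the scatter) and a number 1 percentage points higher from compound 1 to compound 3 (within the scatter). The series thus stays level across an open-chain group and two ring groups, one six-membered and one five-membered, including the change from 0 to 2 hydrogen-bond donors. No evidence at hand explains this flat result. On these data alone, whether a morpholin-4-yl group or a dimethylamino group at this place would move the number beyond the scatter stays open.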